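Aryl Swaps on a Spiro-Fused Core Stay Below Detection

This account rests on a few compounds, and the source may have more. Where it says the series, first, only, none or still open, it means among the compounds named here.

The three measured compounds share one core and differ only in the aryl group attached to an aromatic nitrogen of the five-membered ring with three nitrogens. Compound 1 `N#CC1=C(N)Oc2c(N)cc3nc4ccccc4nc3c2C12C(=O)N(Cc1cnnn1-c1cccc(Br)c1)c1ccccc12` carries a 3-bromophenyl group there. In a functional assay on MCF7 cells (Homo sapiens) for antiproliferative activity, read by MTT assay, with a stated time of 48 h (on this read-out higher numbers stand for weaker inhibition and lower numbers for stronger inhibition), compound 1 reaches only the assay limit of > 50000 nM, a ceiling rather than a measured number. Compound 2 `CC(=O)Nc1ccc(-n2nncc2CN2C(=O)C3(C(C#N)=C(N)Oc4c(N)cc5nc6ccccc6nc5c43)c3ccccc32)cc1` carries a 4-acetamidophenyl group. In this assay compound 2 likewise stops at the limit of > 50000 nM. Compound 3 `CCOc1ccccc1-n1nncc1CN1C(=O)C2(C(C#N)=C(N)Oc3c(N)cc4nc5ccccc5nc4c32)c2ccccc21` carries a 2-ethoxyphenyl group. In this assay compound 3 also gives only the limit of > 50000 nM. Since every value is a limit (the limit of > 50000 nM in this assay, at which 3 of the 3 values shown sit), none of the steps among them can be sized: a step that the two limits leave unreadable from compound 1 to compound 2, a step that the two limits leave unreadable from compound 1 to compound 3 and a step that the two limits leave unreadable from compound 2 to compound 3.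

Compound 4 `N#CC1=C(N)Oc2c(N)cc3nc4ccccc4nc3c2C12C(=O)N(Cc1cnnn1-c1c(F)cccc1F)c1ccccc12` is the next variation: 2,6-difluorophenyl in place of 2-ethoxyphenyl on an aromatic nitrogen. Among the compounds with values here, the measured steps say only that exchanging this aryl group, across three quite different choices, left nothing readable. Within the data shown here, no step pulls in any direction, so the expected step is a step that the limit leaves unreadable from compound 3 to compound 4, again most likely unreadable. The estimate for compound 4 in this assay is 80000 nM, within 30000 nM to 250000 nM, with compound 4 expected to remain at the limit.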

Compound 4, half-maximal inhibitory concentration: > 50000 nM
Compound 4: no number, only a limit; the forecaster's own chance of this, stated with the estimate: 85%; the middle value lies beyond the limit too.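

Compound 4 also gives only a limit, so its steps to compound 1, compound 2 and compound 3 cannot be read, and the four compounds cannot be ranked: the limit of > 50000 nM in this assay, at which 4 of the 4 values shown sit.

The compounds shown leave open whether any aryl group at this position on the shared core can give a measurable value in this assay at all.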